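The source may hold more compounds than are shown below. What is called first, only, known or untested is meant among the compounds shown, and "the series" means these compounds.

In a functional assay on OVCAR-3 cells (Homo sapiens) for inhibition, read by sulforhodamine B assay, with a stated time of 48 h (on this read-out higher numbers stand for weaker inhibition of growth and lower numbers for stronger inhibition of growth), compound 1 `CN1CCN(CCCOc2cccc3nc(Nc4ccc(Cl)c(F)c4)ccc23)CC1` gives 1700 nM. Among the compounds with values here, compound 2 `CN1CCN(CCCOc2cccc3nc(Nc4ccc(F)c(F)c4)ccc23)CC1` gives 4580 nM, the higher of the two numbers, and the single step of a 2.7-fold higher number from compound 1 to compound 2 (0.43 log units; beyond the scatter) separates them. Compound 3 `CN1CCN(CCCOc2cccc3nc(Nc4cc(Cl)cc(Cl)c4)ccc23)CC1` differs from compound 2 by 3,5-dichlorophenyl in place of 3,4-difluorophenyl on a nitrogen on an aromatic ring. Within the data shown here, the only measured step that bears on this change is that exchange of fluoro for chloro, modest yet beyond the scatter, and in compound 3 the move runs back toward chloro. Compound 3 is therefore expected to show a modestly lower number, a step of a 2.3-fold lower number from compound 2 to compound 3 (0.36 log units; beyond the scatter). For compound 3 the estimate is 2000 nM, with a range from 800 nM to 5000 nM.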

Compound 3, concentration for 50% growth inhibition: 1680 nM
Compound 3: the middle estimate sits 1.2-fold (0.08 log units) above what was measured; the measured number falls inside the stated range.
By their numbers in this assay, from the lowest: compounds 3 and 1 (each within the scatter of the next); then compound 2.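

In this assay the move from 3,4-difluorophenyl to 3,5-dichlorophenyl on the nitrogen gives a 2.7-fold lower number from compound 2 to compound 3 (0.44 log units; beyond the scatter) as a modest step beyond the scatter. Set against the 4-chloro-3-fluorophenyl group, the same group gives a 1.0-fold lower number from compound 1 to compound 3 (0.01 log units; within the scatter) and so no difference, which shows that this position tolerates two chlorines as well as one chlorine with one fluorine. Nothing available here explains either step. The compounds shown leave open whether a plain phenyl, or a methoxy or trifluoromethyl group on this ring, would hold the number at this level.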